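The source may report more compounds than this note shows. Statements on the series, on what has been measured and on what is new or still open speak of the compounds shown alone.

Measured compounds:
- compound 1, `Nc1scc(CN2CCN(c3ccc(Cl)cc3F)CC2)c1C(=O)c1ccc(Cl)cc1`: -57%
- compound 2, `Nc1scc(CN2CCN(c3ccccc3C(F)(F)F)CC2)c1C(=O)c1ccc(Cl)cc1`: -39%

These two compounds share one core and differ only in the aryl group on the amine nitrogen of the six-membered non-aromatic ring. In a functional assay on CHO cells with adenosine receptor A1 (Homo sapiens) as the target, read by cAMP accumulation and immunoassay, with a stated time of 6 min, tested at 1 uM (on this read-out higher numbers stand for a weaker effect at the one concentration tested and lower numbers for a stronger effect), compound 1 gives -57% and compound 2 gives -39%. Among the measured compounds shown here, on these two numbers compound 2 stands highest, and the only step known, a number 18 percentage points higher from compound 1 to compound 2 (beyond the scatter), is modest but beyond the scatter.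

Compound 3, `Nc1scc(CN2CCN(c3ccc(Cl)c(C(F)(F)F)c3)CC2)c1C(=O)c1ccc(Cl)cc1`, is not yet measured. It differs from compound 2 at the same place: 4-chloro-3-(trifluoromethyl)phenyl in place of 2-(trifluoromethyl)phenyl on an amine nitrogen in a ring. Compound 3 too changes the aryl group on that ring nitrogen. For the measured compounds named here, the one measured step at that place was a number 18 percentage points higher from compound 1 to compound 2 (beyond the scatter). Compound 3 carries a chlorine, as compound 1 does, together with a trifluoromethyl, as compound 2 does, so a number between the two measured values is expected, with a number 11 percentage points lower from compound 2 to compound 3 (beyond the scatter) as the estimated step. For compound 3 an estimate of -50% is made, with a range from -72% to -26%.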

Compound 3, a percentage reported as activity, at one concentration (the size of the read-out at that concentration, not a potency): -47%
The estimate for compound 3 lay 3 percentage points below the measured number; measured number inside the range.
By their numbers in this assay, from the lowest: compounds 1, 3 and 2 (each within the scatter of the next, the first and the last beyond it).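

In this assay, the step of a number 8 percentage points lower from compound 2 to compound 3 (within the scatter) and the step of a number 10 percentage points higher from compound 1 to compound 3 (within the scatter) place compound 3 within reach of both earlier compounds, so 4-chloro-3-(trifluoromethyl)phenyl on the amine nitrogen in the ring cannot be told apart from either 2-(trifluoromethyl)phenyl or 4-chloro-2-fluorophenyl. The only difference at this position that remains beyond the scatter is the earlier step of a number 18 percentage points higher from compound 1 to compound 2 (beyond the scatter) between the two other aryl groups, and compound 3 does not sharpen it into a trend, since it sits within the scatter of both ends. Nothing is available that would explain these numbers or tie them to any feature of the groups.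

The three compounds leave open whether the read-out at this position responds to anything other than halogen and trifluoromethyl groups on the phenyl ring, such as a methoxy, a nitrile or an amine, or to replacing the phenyl ring with a pyridine. They also leave open how the three aryl groups would compare in potency, as each was read at a single concentration.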